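Acyl group variation on the fused thiazole amide series

A few compounds are considered here, and "the series" means these few. Any claim that something is new, unique, unknown or untested is made for them only; others in the source may bear on it.

In an assay on HEK293 cells for positive allosteric modulation of metabotropic glutamate receptor 5 (Homo sapiens), read by FLIPR, with a stated time of 1 h (on this read-out lower numbers stand for an effect already at smaller amounts and higher numbers for an effect only at larger amounts of compound), compound 2 `O=C(C1CC1)N1CCc2nc(C#Cc3ccccc3)sc2C1` gives only a limit, > 10000 nM. Compound 1 `Fc1cccc(C#Cc2nc3c(s2)CN(C2CCOC2)CC3)c1` likewise gives only a limit, > 10000 nM. Compound 3 `O=C(C1CC(F)(F)C1)N1CCc2nc(C#Cc3cccc(F)c3)sc2C1`, by contrast, gives 2.5 nM. Going by the values given here, the one measured step that concerns the amine nitrogen in the ring is an at least 4000-fold lower number from compound 1 to compound 3 (3.60 log units; beyond the scatter), a change from a plain ring substituent to a carbonyl-bearing one; compound 2 already carries a carbonyl there, so this step bears only loosely on what follows. Compound 4 `O=C(CC1CCOCC1)N1CCc2nc(C#Cc3ccccc3)sc2C1` differs from compound 2 by (oxan-4-yl)methyl in place of cyclopropyl on a carbonyl carbon. Both compounds are amides, so the step is a change of acyl group size and shape rather than of functional type. The two limits the limit of > 10000 nM in this assay, at which 2 of the 3 values shown sit, leave the position of compound 2 itself open. The expectation for compound 4 is therefore a step of an at least 6.6-fold lower number from compound 2 to compound 4 (0.82 log units; beyond the scatter), in the direction of a lower number, with wide uncertainty. Compound 4 is estimated at 1500 nM, within 100 nM to 10000 nM.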

Compound 4, half-maximal effective concentration: 470 nM
Estimate against measurement, compound 4: 3.2-fold (0.50 log units) above; the range from low to high includes it.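

Exchanging cyclopropyl for (oxan-4-yl)methyl on a carbonyl carbon gives an at least 21-fold lower number from compound 2 to compound 4 (1.32 log units; beyond the scatter) in this assay. The amide is kept in this pair, so the choice of acyl group alone moves the read-out, whereas the earlier step replaced oxolan-3-yl with an acyl group and so changed the type of substituent on the ring nitrogen. Compound 2 stands at a limit, so the step gives only a lower bound on the true gap: the limit of > 10000 nM in this assay, at which 2 of the 4 values shown sit.

The ring oxygen, the added methyl link and the larger ring all enter together in this pair, and the share of each remains unresolved. Cyclohexylmethyl or oxan-4-yl placed directly on the carbonyl carbon would separate these contributions, and an acyl group carrying an amine remains an open case.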